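This account rests on a few compounds, and the source may have more. Where it says the series, first, only, none or still open, it means among the compounds named here.

Working notes on the series. Within the data shown here, compound 3 `C=C(Br)C(=O)Nc1cccc(-c2cn3nc(Cc4ccc(Cl)cc4)sc3n2)c1` stands second highest of the three numbers so far: in a functional assay on HeLa cells (Homo sapiens) for inhibition, read by cell counting, with a stated time of 4 days (on this read-out higher numbers stand for weaker inhibition and lower numbers for stronger inhibition), compound 3 gives 2700 nM. Compound 1 `C=C(Br)C(=O)Nc1cccc(-c2cn3nc(Cc4cccc(OC)c4)sc3n2)c1` gives 2500 nM in this assay, and compound 2 `C=C(Br)C(=O)Nc1cccc(-c2cn3nc(Cc4ccccc4)sc3n2)c1` gives 4500 nM. All measured steps stay within the scatter: a 1.8-fold higher number from compound 1 to compound 2 (0.26 log units; within the scatter), a 1.7-fold lower number from compound 2 to compound 3 (0.22 log units; within the scatter), and a 1.1-fold higher number from compound 1 to compound 3 (0.03 log units; within the scatter). Compound 4 `C=C(Br)C(=O)Nc1cccc(-c2cn3nc(-c4cccs4)sc3n2)c1` brings a different kind of change: thiophen-2-yl in place of 4-chlorobenzyl on an aromatic carbon. The measured steps only swap or decorate a benzyl group, so none of them bears directly on removing the benzyl altogether; they show that modest edits at this position leave the number roughly where it is. No step beyond the scatter is therefore expected, with wide uncertainty: compound 4 is estimated at 4000 nM, range 1200 nM to 13000 nM, meaning an expected step of a 1.5-fold higher number from compound 3 to compound 4 (0.17 log units; within the scatter).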

Compound 4, half-maximal inhibitory concentration: 670 nM
For compound 4 the middle estimate is 6.0-fold (0.78 log units) above the measured one; measured number outside the range, below it.
By their numbers in this assay, from the lowest: compound 4; then compounds 1, 3 and 2 (each within the scatter of the next).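

Thiophen-2-yl on this aromatic carbon gives a clear shift in this assay where edits to the benzyl ring did not: a 4.0-fold lower number from compound 3 to compound 4 (0.61 log units; beyond the scatter) and a 6.7-fold lower number from compound 2 to compound 4 (0.83 log units; beyond the scatter) and a 3.7-fold lower number from compound 1 to compound 4 (0.57 log units; beyond the scatter) all lie beyond the scatter. Compound 4 is thus the strongest of the four, so this position does respond when the benzyl group as a whole is replaced. No evidence on hand accounts for this shift. The compounds shown leave open whether the lower number goes with losing the benzyl chain carbon or with the thiophene ring itself. A phenyl group bound to this same aromatic carbon would separate the two.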